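The source may hold more compounds than are shown below. What is called first, only, known or untested is meant among the compounds shown, and "the series" means these compounds.

Measured so far in an ADME assay on MT4 cells (Homo sapiens) for cytotoxicity, read by MTT assay; on this read-out lower numbers stand for higher toxicity in this test and higher numbers for lower toxicity in this test:
- compound 1 `CCOC(=O)/C(O)=C/C(=O)c1cn(Cc2cc(F)c(F)c(F)c2)c2cccc(OC)c12` gives 33400 nM
- compound 2 `CCOC(=O)/C(O)=C/C(=O)c1cn(Cc2c(F)cccc2F)c2cccc(OC)c12` gives 63400 nM

Compound 2 holds the higher of the two numbers, but the step of a 1.9-fold higher number from compound 1 to compound 2 (0.28 log units; within the scatter) lies within the scatter, so on this assay the two compounds are not separated.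

Compound 3 `CCOC(=O)/C(O)=C/C(=O)c1cn(Cc2cc(F)ccc2F)c2cccc(OC)c12` is the next member. It differs from compound 2 by 2,5-difluorophenyl in place of 2,6-difluorophenyl on a saturated chain carbon bound to an aromatic nitrogen. Going by the values given here, the only measured step that bears on this place is a 1.9-fold higher number from compound 1 to compound 2 (0.28 log units; within the scatter), a rearrangement of fluorines on the same benzyl group that stayed within the scatter. Nothing in the series shows that moving fluorines around this ring shifts this assay beyond its scatter, so the step of a 1.4-fold lower number from compound 2 to compound 3 (0.15 log units; within the scatter) is expected to stay within it, with no set direction. Compound 3 is estimated at 45000 nM, within 20000 nM to 100000 nM.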

Compound 3, half-maximal cytotoxic concentration: 41200 nM
For compound 3 the middle estimate is 1.1-fold (0.04 log units) above the measured one; the measured number falls inside the stated range.
By their numbers in this assay, from the lowest: compounds 1, 3 and 2 (each within the scatter of the next).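

Taking 2,5-difluorobenzyl in place of 2,6-difluorobenzyl, with the same atoms joined differently, gives a 1.5-fold lower number from compound 2 to compound 3 (0.19 log units; within the scatter) in this assay and lies within the scatter, so a pure rearrangement of the two fluorines does not separate the compounds, whereas the earlier step also changed the fluorine count. The step of a 1.2-fold higher number from compound 1 to compound 3 (0.09 log units; within the scatter) also lies within the scatter, leaving all three fluorinated benzyl groups at this place, on a saturated chain carbon bound to an aromatic nitrogen, unseparated. No supporting data are available to interpret these numbers.

Going by these compounds, whether a benzyl group without fluorine, or one carrying an amine, would move the read-out beyond the scatter remains open. So does whether a carboxylic acid in place of the ethyl ester on the shared core would do so.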